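This account rests on a few compounds, and the source may have more. Where it says the series, first, only, none or still open, it means among the compounds named here.

Measured in an ADME assay on L123 cells (Homo sapiens) for cytotoxicity, read by MTT assay, with a stated time of 48 h; a lower number here means a stronger inhibitor, a higher number a weaker inhibitor:
Compound 1 `COc1cc(/C=C/c2cc(/C=C/c3ccc(O)c(OC)c3)n(C(N)=O)n2)ccc1O`: "not determined" (no result reported)
Compound 2 `COc1cc(/C=C/c2cc(/C=C/c3ccc(O)c(OC)c3)n(C(=O)c3ccncc3)n2)ccc1O`: > 100000000 nM

Compound 1 offers no number for comparison, so the series rests on compound 2 alone. Compound 2 stands at a limit of the assay, > 100000000 nM, and not at a number. Among the measured compounds shown here, no measured step yet shows how far a change at the aromatic nitrogen can move the read-out in this assay.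

Compound 3 `COc1cc(/C=C/c2cc(/C=C/c3ccc(O)c(OC)c3)n(-c3ccc([N+](=O)[O-])cc3[N+](=O)[O-])n2)ccc1O` keeps the shared core and carries 2,4-dinitrophenyl in place of (pyridin-4-yl)carbonyl on an aromatic nitrogen. Only a small move toward stronger inhibition is expected, an estimated at least 1.6-fold lower number from compound 2 to compound 3 (0.22 log units; that floor lies within the scatter), and a limit may well be reported again. For compound 3 the expected value is estimated at 60000000 nM, with an expected range of 5000000 nM to 200000000 nM.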

Compound 3, half-maximal inhibitory concentration: > 100000000 nM
Compound 3 was reported as a limit; the forecaster's own chance of this, stated with the estimate: 60%; middle value at least 1.6-fold (0.22 log units) from the limit.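

Compound 3 gives only a limit, > 100000000 nM, and not a number. Compound 2 also stands at a limit, so the step between compound 2 and compound 3 cannot be read. The compounds shown leave open whether any change on that aromatic nitrogen can bring the read-out to a single number.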